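Sulfonamide aryl variation on the shared core: chloro for methoxy

The source may report more compounds than this note shows. Statements on the series, on what has been measured and on what is new or still open speak of the compounds shown alone.

Compound 3 `COc1cccc(S(=O)(=O)Nc2ccc(-c3nc4ccccc4o3)cc2)c1` stands at the higher of the two numbered values in an assay on cells for inhibition of HSP60/HSP10 (Homo sapiens), with a stated time of 60 min (a lower number here means a stronger inhibitor, a higher number a weaker inhibitor), where compound 3 gives 80000 nM. Compound 1 `O=S(=O)(Nc1ccc(-c2nc3ccccc3o2)cc1)c1ccc(Cl)c(C(F)(F)F)c1`, which carries a 4-chloro-3-trifluoromethylphenyl on the sulfonyl sulfur, in this assay gives 12000 nM. Compound 2 `C=Cc1ccc(S(=O)(=O)Nc2ccc(-c3nc4ccccc4o3)cc2)cc1` reaches only a limit of this assay, and compound 2 is recorded as > 100000 nM. Among the measured compounds shown here, the single step measured, an at least 1.2-fold lower number from compound 2 to compound 3 (0.09 log units; that floor lies within the scatter), rests on that limit, and its floor lies within the scatter, so it sets no size.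

Compound 4 `O=S(=O)(Nc1ccc(-c2nc3ccccc3o2)cc1)c1ccc(Cl)cc1` is the next entry: 4-chlorophenyl in place of 3-methoxyphenyl on a sulfonyl sulfur. For the measured compounds named here, no measured step bears directly on this change. Compound 1 and compound 3 differ in two places and are not a single step; their values only show that the entry carrying chlorine on the aryl sits at the lower number. The limit of the limit of > 100000 nM in this assay, at which 1 of the 3 values shown sits, marks where numbers cease in this assay.

For compound 4 the estimate in this assay is 30000 nM, within 10000 nM to 100000 nM, because compound 1 gives 12000 nM. The expected step of a 2.7-fold lower number from compound 3 to compound 4 (0.43 log units; beyond the scatter) is toward a lower number and of moderate size, with a real chance that only a limit is returned.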

Compound 4, half-maximal inhibitory concentration: 61000 nM
Beside the measured number, compound 4's estimate is 2.0-fold (0.31 log units) below it; measured number inside the range.
By their numbers in this assay, from the lowest: compound 1; then compounds 4 and 3 (each within the scatter of the next). At a limit, above all of these: compound 2.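

In this assay 4-chlorophenyl in place of 3-methoxyphenyl on a sulfonyl sulfur gives a 1.3-fold lower number from compound 3 to compound 4 (0.12 log units; within the scatter) and so chlorine on the aryl ring does not by itself separate compound 4 from compound 3. The step with hydrogen in place of trifluoromethyl on an aromatic carbon (a 5.1-fold higher number from compound 1 to compound 4 (0.71 log units; beyond the scatter)) lies beyond the scatter, so among the compounds shown the lower number of compound 1 goes with the trifluoromethyl and not with the chlorine alone. The step with chloro in place of vinyl on an aromatic carbon (an at least 1.6-fold lower number from compound 2 to compound 4 (0.21 log units; that floor lies within the scatter)) rests on a limit and sets no size. Compound 2 stands at a limit: the limit of > 100000 nM in this assay, at which 1 of the 4 values shown sits.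

Among the compounds shown here, still open is whether the trifluoromethyl keeps the number of compound 1 without the chlorine on the same aryl ring, or whether only the pair of groups does so. Also open, on these data alone, is how a nitrile, a carboxylic acid or an amine would read in this assay at the aromatic carbon that carries trifluoromethyl in compound 1.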